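Dihydroxyphenyl in place of dimethoxyphenyl: compound 2 to compound 4

The source may hold more compounds than are shown below. What is called first, only, known or untested is meant among the compounds shown, and "the series" means these compounds.

In a functional assay on HeLa cells (Homo sapiens) for inhibition, read by CCK-8 assay, with a stated time of 48 h (a lower number here means a stronger inhibitor, a higher number a weaker inhibitor), compound 2 (`COc1ccc(Oc2ccc(C(C)C)cc2-c2ccsc2S(=O)(=O)NCCNC(=O)Nc2cc(Cl)cc(Cl)c2)cc1OC`) gives 11600 nM. This stands level with compound 1 (`COc1ccc(Oc2ccc(C(C)C)cc2-c2ccsc2S(=O)(=O)NCCNC(=S)Nc2ccc([N+](=O)[O-])cc2)cc1OC`) at 11900 nM and compound 3 (`O=C(NCCNS(=O)(=O)c1ccc(-c2ccccc2O[C@H]2CC[C@H](O)CC2)s1)Nc1ccc([N+](=O)[O-])cc1`) at 10500 nM, and all three values lie within the scatter of one another.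

Compound 4 (`CC(C)c1ccc(Oc2ccc(O)c(O)c2)c(-c2ccsc2S(=O)(=O)NCCNC(=O)Nc2cc(Cl)cc(Cl)c2)c1`) differs from compound 2 in one place: 3,4-dihydroxyphenyl in place of 3,4-dimethoxyphenyl on an oxygen on an aromatic ring. In words, this is 3,4-dihydroxyphenyl in place of 3,4-dimethoxyphenyl on an oxygen on an aromatic ring.

Going by the values given here, only one measured step is available, a 1.0-fold lower number from compound 1 to compound 2 (0.01 log units; within the scatter), and it lies within the scatter. That step alters a group on an amine nitrogen and leaves the 3,4-dimethoxyphenyl untouched, so it bears on the present change only indirectly. Among the compounds with values here, no measured pair tests the present change itself. From the compounds shown here alone, with that single step as the guide, no shift beyond the scatter is expected in this assay, and the direction stays open. The expected step is a 1.3-fold lower number from compound 2 to compound 4 (0.11 log units; within the scatter), with wide uncertainty. For compound 4 the estimated value is 9000 nM, with an expected range of 3000 nM to 25000 nM.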

Compound 4, half-maximal inhibitory concentration: > 50000 nM
Compound 4 ended at the assay's limit; the forecaster's own chance of this, stated with the estimate: 12%; middle value at least 5.5-fold (0.74 log units) from the limit.
By their numbers in this assay, from the lowest: compounds 3, 2 and 1 (each within the scatter of the next). At a limit, above all of these: compound 4.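

In this assay compound 4 stands at a limit of the assay, not at a number: the limit of > 50000 nM in this assay, at which 1 of the 4 values shown sits. The change from 3,4-dimethoxyphenyl to 3,4-dihydroxyphenyl on this oxygen gives an at least 4.3-fold higher number from compound 2 to compound 4 (0.63 log units; beyond the scatter), whereas the earlier change on an amine nitrogen gave a 1.0-fold lower number from compound 1 to compound 2 (0.01 log units; within the scatter). This oxygen substituent is therefore the first place in the series where one change moves the read-out beyond the scatter, and the move is towards weaker inhibition.

Both methoxy groups change together in this pair, so the compounds shown do not tell whether one hydroxyl alone would have the same outcome. They also do not tell how a plain phenyl, or a phenyl carrying an amine or a carboxylic acid, would read on this oxygen.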